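Benzyl to Methyl Ester: Expected Value for Compound 4

A few compounds are considered here, and "the series" means these few. Any claim that something is new, unique, unknown or untested is made for them only; others in the source may bear on it.

Measured so far in an ADME assay on WI-38 cells (Homo sapiens) for inhibition, read by CellTiter-Glo, with a stated time of 48 h, tested at 100 uM; on this read-out higher numbers stand for more inhibition at the one concentration tested (going by the name of the read-out) and lower numbers for less inhibition:
compound 1 `CC(C)(CO)[C@H](O)C(=O)N/C=C/C(=O)OCc1ccccc1` gives 19%;
compound 2 `COC(=O)/C=C/NC(=O)[C@@H](O)C(C)(C)CO` gives -18%;
compound 3 `CC(C)(CO)[C@@H](O)C(=O)N/C=C/C(=O)OCc1ccccc1` gives 19%.

Compound 1 and compound 3 share every atom and bond and differ only as set out in the two compounds have the same atoms and bonds and differ only in configuration as drawn: 1 of 2 stereo elements differ; a stereocentre at a saturated chain carbon is drawn S in compound 1 and R in compound 3. In this assay the step of no change at the digits printed from compound 1 to compound 3 (within the scatter) stays within the scatter, which fits because the fact that compounds 1 and 3 differ only in the configuration as drawn shows the two compounds to be mirror-drawn at one centre only.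

Compound 2 arises from compound 1 through (hydrogen in place of phenyl on a saturated chain carbon bound to an oxygen next to a carbonyl group), and the step of a number 37 percentage points lower from compound 1 to compound 2 (beyond the scatter) is large. Compound 4 `COC(=O)/C=C/NC(=O)[C@H](O)C(C)(C)CO` applies the same change to compound 3, namely (hydrogen in place of phenyl on a saturated chain carbon bound to an oxygen next to a carbonyl group), at a place described in identical words, so it is the same change. Since compound 3 stands level with compound 1, the step of a number 37 percentage points lower from compound 3 to compound 4 (beyond the scatter) is expected to mirror that earlier drop. Compound 4 is therefore estimated at -18%, most likely between -32% and -4%.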

Compound 4, a percentage reported as inhibition, at one concentration (the size of the read-out at that concentration, not a potency): 4%
Compound 4: middle estimate off by 22 percentage points, on the low side; the whole stated range lies below it.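

Going from benzyl to methyl on the core of compound 3 gives a number 15 percentage points lower from compound 3 to compound 4 (beyond the scatter), so the direction carries over from the earlier pair but the size does not: the same change on two cores in this assay, a number 37 percentage points lower (beyond the scatter) from compound 1 to compound 2 and a number 15 percentage points lower (beyond the scatter) from compound 3 to compound 4, 22 percentage points apart, beyond the scatter of two such steps

The two methyl esters also part at the one stereocentre, with a number 22 percentage points higher from compound 2 to compound 4 (beyond the scatter), while the two benzyl esters show no change at the digits printed: the fact that compounds 2 and 4 differ only in the configuration as drawn

So in these four compounds the size of the step goes with the configuration as drawn, but this does not explain why, and two pairs set no rule for other cores.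

Going by these compounds, what an ethyl group or a longer chain would give in place of the benzyl or methyl stays open. So does the effect of a carboxylic acid in place of the ester.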